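The source may hold more compounds than are shown below. What is called first, only, known or untested is meant among the compounds shown, and "the series" means these compounds.

- Compound 1 `COc1cc(OC)c(-c2coc3cc(OCC=C(C)C)ccc3c2=O)cc1OC`: 680 nM
- Compound 2 `COc1cc(OC)c(-c2coc3cc(OCc4ccccc4)ccc3c2=O)cc1OC`: 2280 nM

In a functional assay on HCT-116 cells (Homo sapiens) for antiproliferative activity, read by MTT assay, with a stated time of 24 h (on this read-out lower numbers stand for stronger inhibition and higher numbers for weaker inhibition), compound 2 gives 2280 nM, the higher of the two numbers and therefore the weaker inhibition of the pair. Compound 3 `COc1cc(OC)c(-c2coc3cc(OCC(=O)c4cccc(C(F)(F)F)c4)ccc3c2=O)cc1OC` keeps the shared core and differs from compound 2 in one place: (3-(trifluoromethyl)phenyl)carbonyl in place of phenyl on a saturated chain carbon bound to an oxygen on an aromatic ring. In words, (3-(trifluoromethyl)phenyl)carbonyl stands in place of phenyl on a saturated chain carbon bound to an oxygen on an aromatic ring.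

Among the compounds with values here, only one measured step bears on this change: a 3.4-fold higher number from compound 1 to compound 2 (0.53 log units; beyond the scatter). It is modest and involves the same place, so a step of similar size seems a reasonable expectation. Within the data shown here, no measured compound carries the incoming group, so the direction stays open, with only a slight lean towards a lower number. The expected step is a 1.5-fold lower number from compound 2 to compound 3 (0.18 log units; within the scatter). The estimated value for compound 3 is 1500 nM, with an expected range of 400 nM to 5500 nM.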

Compound 3, half-maximal inhibitory concentration: > 10000 nM
Compound 3: a limit, no number; the forecaster's own chance of this, stated with the estimate: 5%; at least 6.6-fold (0.82 log units) between middle value and limit.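

In this assay compound 3 gives only a limit, not a number: the limit of > 10000 nM in this assay, at which 1 of the 3 values shown sits. The change of phenyl to (3-(trifluoromethyl)phenyl)carbonyl on a saturated chain carbon bound to an oxygen on an aromatic ring brings an at least 4.3-fold higher number from compound 2 to compound 3 (0.64 log units; beyond the scatter), and the change from 2-methylprop-1-en-1-yl to the same group brings an at least 14-fold higher number from compound 1 to compound 3 (1.16 log units; beyond the scatter). This place can therefore cost far more activity than the modest step between the first two compounds showed, and the full size of that cost lies hidden behind the limit.

The carbonyl and the trifluoromethyl group enter together in compound 3, so the compounds shown cannot say which of them matters, or whether both do. From the compounds shown here alone, how an amine or a carboxylic acid at this place would behave also stays open.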